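Compound 3 to compound 4: moving the nitro group

The compounds below may be only part of what the source reports. "The series", "measured", "known", "first", "only" and "open" are said of these compounds alone.

Measured compounds:
compound 1 `CCCCCCCCCCCCn1nnc(C(NC(=O)c2ccc(F)cc2F)c2ccccc2)n1` — 490 nM
compound 2 `CCCCCCCCCCCCn1nnc(C(NC(=O)c2ccc(OC)cc2)c2ccccc2)n1` — 600 nM
compound 3 `CCCCCCCCCCCCn1nnc(C(NC(=O)c2cccc([N+](=O)[O-])c2)c2ccccc2)n1` — 80 nM

In an assay on microsomes from liver for inhibition of sterol O-acyltransferase 1 (Rattus norvegicus) (on this read-out lower numbers stand for stronger inhibition and higher numbers for weaker inhibition), compound 3 stands lowest of the three numbers: the steps of a 6.1-fold lower number from compound 1 to compound 3 (0.79 log units; beyond the scatter) and a 7.5-fold lower number from compound 2 to compound 3 (0.88 log units; beyond the scatter) both lie beyond the scatter, whereas a 1.2-fold higher number from compound 1 to compound 2 (0.09 log units; within the scatter). Compound 4 `CCCCCCCCCCCCn1nnc(C(NC(=O)c2ccc([N+](=O)[O-])cc2)c2ccccc2)n1` keeps the same atoms as compound 3 and differs only in where the nitro group sits: 4-nitrophenyl in place of 3-nitrophenyl on a carbonyl carbon. Among the compounds with values here, no measured step bears directly on this change; the steps seen so far swap one whole group for another on the carbonyl carbon, and none moves a group within the same ring. Compound 4 is therefore expected to give 150 nM, with a wide range from 40 nM to 600 nM. The expected step is a 1.9-fold higher number from compound 3 to compound 4 (0.27 log units; within the scatter).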

Compound 4, half-maximal inhibitory concentration: 540 nM
The estimate for compound 4 lay 3.6-fold (0.56 log units) below the measured number; the measured number falls inside the stated range.
By their numbers in this assay, from the lowest: compound 3; then compounds 1, 4 and 2 (each within the scatter of the next).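

In this assay, moving the nitro group alone changes the result (a 6.8-fold higher number from compound 3 to compound 4 (0.83 log units; beyond the scatter)), so the low number of compound 3 belongs to 3-nitrophenyl on the carbonyl carbon and not to a nitro group as such. The 4-nitrophenyl group does not set compound 4 apart from the other two amides (a 1.1-fold lower number from compound 2 to compound 4 (0.05 log units; within the scatter); a 1.1-fold higher number from compound 1 to compound 4 (0.04 log units; within the scatter)). Nothing available here explains this dependence on where the nitro group sits. The compounds shown leave open whether an amine, a nitrile or a carboxylic acid, placed where the nitro group stands in 3-nitrophenyl, would keep the low number of compound 3.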